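The source may hold more compounds than are shown below. What is called first, only, known or untested is meant among the compounds shown, and "the series" means these compounds.

The shared core of compound 1 `CCc1cccc(NC(=O)CN2CCC(c3cccc[n+]3[O-])CC2)c1` carries an amide-type nitrogen whose substituent varies across the set. In a functional assay on HEK293 cells for agonist activity at D(4) dopamine receptor (Homo sapiens), read by FLIPR (a lower number here means a smaller maximal response, a higher number a larger maximal response), compound 1 gives 62%, the second highest of three numbers, with compound 3 `O=C(CN1CCC(c2cccc[n+]2[O-])CC1)Nc1ccccc1F` nearest at 63% and compound 2 `O=C(CN1CCC(c2cccc[n+]2[O-])CC1)NC1CCCCC1` furthest at 58%. The measured steps are a number 4 percentage points lower from compound 1 to compound 2 (within the scatter), a number 1 percentage points higher from compound 1 to compound 3 (within the scatter) and a number 5 percentage points higher from compound 2 to compound 3 (within the scatter), so swapping cyclohexyl, 3-ethylphenyl and 2-fluorophenyl on the amide-type nitrogen keeps the maximal response within the scatter throughout. Compound 4 `O=C(CN1CCC(c2cccc[n+]2[O-])CC1)Nc1cccc(C(F)(F)F)c1` keeps the core and differs from compound 1 by trifluoromethyl in place of ethyl on an aromatic carbon. Going by the values given here, no measured step alters a substituent on that aromatic ring itself; the bearing steps are only the three above, each within the scatter, and they point to a flat response to changes at this end of the molecule. The expectation for compound 4 is therefore no step beyond the scatter, a number 1 percentage points lower from compound 1 to compound 4 (within the scatter). Compound 4 is estimated at 61%, with a range from 50% to 72%.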

Compound 4, largest response reached (reported as efficacy), in percent of the reference or control that the assay uses: 75%
Compound 4: middle estimate off by 14 percentage points, on the low side; measured number outside the range, above it.
By their numbers in this assay, from the lowest: compounds 2, 1 and 3 (each within the scatter of the next); then compound 4.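

In this assay, going by these compounds alone, trifluoromethyl in place of ethyl on the aromatic carbon gives a number 13 percentage points higher from compound 1 to compound 4 (beyond the scatter) and is the first single change to move the maximal response beyond the scatter. The three earlier steps all changed the whole substituent on the amide-type nitrogen and stayed within the scatter, so the flat picture does not hold for this change on the aromatic ring, although the step is modest and rests on a single pair. No measurement at hand bears on this step, and it stands without an explanation.

From the compounds shown here alone, whether the rise is specific to trifluoromethyl or would also appear with chlorine, methoxy or a nitrile on the same carbon remains open. Equally open, going by these compounds, is whether trifluoromethyl gives a similar step on another carbon of the ring.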